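A few compounds are considered here, and "the series" means these few. Any claim that something is new, unique, unknown or untested is made for them only; others in the source may bear on it.

Series notes. Compound 1 `CCCC(=O)N1CCC(c2cc(OC)ccc2N)=N1` gives 13.1% in an assay on isolated protein for inhibition of Nitric oxide synthase, inducible (Homo sapiens), with a stated time of 30 min, tested at 1 mM; a lower number here means less inhibition, a higher number more inhibition at the concentration tested (going by the name of the read-out). Among the compounds with values here, compound 2 `CCCCC(=O)N1CCC(c2cc(OC)ccc2N)=N1` gives 0.18% in this assay, the lower of the two numbers so far, and the step of a number 12.9 percentage points lower from compound 1 to compound 2 (beyond the scatter) is the only one measured. Compound 3 `COc1ccc(N)c(C2=NN(C(=O)C3CCC3)CC2)c1` differs from compound 2 by cyclobutyl in place of butyl on a carbonyl carbon. Within the data shown here, no measured step covers this change; the single known step does not involve it, so it offers little guidance. Compound 3 is therefore expected to stay near compound 2, a step of about a number 4.8 percentage points higher from compound 2 to compound 3 (within the scatter) in this assay, within the scatter. The estimate for compound 3 is 5%, with a range of 0% to 20%.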

Compound 3, a percentage reported as inhibition, at one concentration (the size of the read-out at that concentration, not a potency): 1.91%
Compound 3: the middle estimate sits 3.1 percentage points above what was measured; low and high end bracket the measured number.
By their numbers in this assay, from the lowest: compounds 2 and 3 (each within the scatter of the next); then compound 1.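

Cyclobutyl and butyl on the carbonyl carbon cannot be told apart in this assay, with a step of a number 1.7 percentage points higher from compound 2 to compound 3 (within the scatter). Cyclobutyl in place of propyl gives a number 11.2 percentage points lower from compound 1 to compound 3 (beyond the scatter), so a ring of the same heavy-atom count as butyl also stands apart from compound 1. No supporting data bear on these steps. From the compounds shown here alone, what stays open is whether a longer chain than butyl, a cyclopropyl ring or an amine on the carbonyl carbon would read differently from compound 2 and compound 3.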